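Amide Variation at the Ring Nitrogen of a Toll-like Receptor 8 Agonist

A few compounds are considered here, and "the series" means these few. Any claim that something is new, unique, unknown or untested is made for them only; others in the source may bear on it.

Compound 2 `CCCCNc1nc(N)nc2c1CN(C(=O)CC)CC2` gives 0.4 uM in an assay on HEK293 cells for agonist activity at Toll-like receptor 8 (Homo sapiens), read by a luciferase reporter, with a stated time of 6 h (on this read-out lower numbers stand for an effect already at smaller amounts and higher numbers for an effect only at larger amounts of compound), the higher of the two measured numbers; compound 1 `CCCCNc1nc(N)nc2c1CN(Cc1ccccc1Cl)CC2` gives 0.05 uM, and the step of an 8.0-fold higher number from compound 1 to compound 2 (0.90 log units; beyond the scatter) shows what the aromatic-to-acyl swap cost. Compound 3 `CCCCNc1nc(N)nc2c1CN(C(=O)c1ccccn1)CC2` differs from compound 2 only by pyridin-2-yl in place of ethyl on a carbonyl carbon. Among the measured compounds shown here, no measured step covers an acyl-to-acyl exchange, so the expectation rests on compound 1 returning an aromatic ring to the same nitrogen. Compound 3 is therefore expected to give a lower number, around 0.1 uM (range 0.03 uM to 0.4 uM), a step of a 4.0-fold lower number from compound 2 to compound 3 (0.60 log units; beyond the scatter).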

Compound 3, minimum effective concentration: 2.9 uM
Compound 3: middle estimate off by 29-fold (1.46 log units), on the low side; the measured number lies above the stated range.
By their numbers in this assay, from the lowest: compound 1; then compound 2; then compound 3.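

Pyridin-2-yl in place of ethyl on a carbonyl carbon gives a 7.3-fold higher number from compound 2 to compound 3 (0.86 log units; beyond the scatter) in this assay and so moves the number up, not down, while (pyridin-2-yl)carbonyl in place of 2-chlorobenzyl gives a 58-fold higher number from compound 1 to compound 3 (1.76 log units; beyond the scatter) at the same nitrogen. An aromatic ring at this position therefore does not by itself go with a low number: of the two compounds carrying one, compound 1 has the lowest number and compound 3 the highest. No evidence at hand bears on this rise.

The compounds shown leave open whether phenyl on the carbonyl carbon would behave like pyridin-2-yl, and whether a longer chain in place of ethyl would keep the number near that of compound 2.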